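Two weak cytotoxic amides and an untested third

This account rests on a few compounds, and the source may have more. Where it says the series, first, only, none or still open, it means among the compounds named here.

Compound 1 `CCCCCCCCCCCCCCNC(=O)[C@H](CO)/N=C/c1ccc([N+](=O)[O-])cc1` and compound 2 `CCCCCCCCCCCCCCNC(=O)[C@H](CO)NCc1ccccc1OC` were both tested in a functional assay on cells (Homo sapiens) for cytotoxicity, read by MTT assay, with a stated time of 24 h; on this read-out higher numbers stand for weaker inhibition and lower numbers for stronger inhibition. In this assay compound 1 gives 217000 nM. In this assay compound 2 gives 100000 nM, the lowest of the two numbers, and the gap to compound 1 is beyond the usual scatter. Within the data shown here, the two compounds differ in more than one place, so no single step between them can be named. Compound 3 `CCCCCCCCCCCCCCNC(=O)[C@H](CO)/N=C/c1ccc(OC)cc1` has not yet been measured. It differs from compound 2 by a group of 10 heavy atoms (8 carbon, 1 nitrogen, 1 oxygen; one six-membered aromatic ring of carbon only) in place of a group of 10 heavy atoms (8 carbon, 1 nitrogen, 1 oxygen; one six-membered aromatic ring of carbon only), on a saturated chain carbon bound to a carbonyl carbon and a saturated chain carbon, so it keeps the long chain, the amide and the shared core, but exchanges the (2-methoxybenzyl)amino group for a group that carries one double bond outside aromatic rings and no hydrogen-bond donor. Compound 1 carries a group of the same kind on the same place and gives 217000 nM in this assay; compound 3 is therefore expected to land near or somewhat above compound 2, a step of a 1.5-fold higher number from compound 2 to compound 3 (0.18 log units; within the scatter) that may not exceed the scatter. For compound 3 the estimated value in this assay is 150000 nM, with a range from 60000 nM to 400000 nM.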

Compound 3, half-maximal inhibitory concentration: 28100 nM
Beside the measured number, compound 3's estimate is 5.3-fold (0.73 log units) above it; the whole stated range lies above it.
By their numbers in this assay, from the lowest: compound 3; then compound 2; then compound 1.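

In this assay the group on the saturated chain carbon bound to a carbonyl carbon and a saturated chain carbon clearly counts: exchanging the (2-methoxybenzyl)amino group for a group with a double bond outside aromatic rings and no hydrogen-bond donor gives a 3.6-fold lower number from compound 2 to compound 3 (0.55 log units; beyond the scatter) and makes compound 3 the lowest of the three numbers. Compound 1 alone might have tied that kind of group to a high number, but methoxy in place of nitro on an aromatic carbon gives a 7.7-fold lower number from compound 1 to compound 3 (0.89 log units; beyond the scatter), so what the aromatic ring carries matters as well. No measurement shown here gives a reason for either step.

The compounds shown leave open whether a chlorine or a dimethylamino group in place of the methoxy would lower the number further, and whether a shorter chain in place of the long one would keep it. The groups of compound 2 and compound 3 also differ in more than the double bond, so a pair that changes only that bond, with the aromatic part kept the same, would be needed to tell how much of the step belongs to it.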